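The source may report more compounds than this note shows. Statements on the series, on what has been measured and on what is new or still open speak of the compounds shown alone.

Compound 2 `COC(=O)c1cc(NCc2ccccc2[N+](=O)[O-])c2cn[nH]c2c1` gives 16% in an assay for inhibition of Tryptophan 2,3-dioxygenase (Homo sapiens), with stated times of 10 min and 60 min, tested at 10 uM; on this read-out higher numbers stand for a stronger effect at the one concentration tested and lower numbers for a weaker effect. Among the measured compounds shown here, that is the lowest of the three numbers measured so far: compound 1 `O=[N+]([O-])c1ccccc1CNc1cccc2[nH]ncc12` gives 45% in this assay, and compound 3 `O=[N+]([O-])c1ccc(CNc2cc(C(F)(F)F)cc3[nH]ncc23)cc1` gives 47% in this assay. Compound 4 `O=[N+]([O-])c1ccccc1CNc1cc(C(F)(F)F)cc2[nH]ncc12` has not yet been tested. It differs from compound 2 in one place: trifluoromethyl in place of methoxycarbonyl on an aromatic carbon. For the measured compounds named here, the one measured step that bears on this change is a number 29 percentage points lower from compound 1 to compound 2 (beyond the scatter), where the methoxycarbonyl entered in place of hydrogen; taking it away again in compound 4 would be expected to undo that loss. Compound 3 carries a trifluoromethyl and gives a number close to that of compound 1, which carries none, but those two compounds also differ in a second place, so the contribution of the trifluoromethyl by itself cannot be separated. Compound 4 is therefore expected to show a number 29 percentage points higher from compound 2 to compound 4 (beyond the scatter) in this assay. Compound 4 is estimated at 45%, with a likely range from 25% to 65%.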

Compound 4, a percentage reported as inhibition, at one concentration (the size of the read-out at that concentration, not a potency): 89%
Estimate against measurement, compound 4: 44 percentage points below; the whole stated range lies below it.
By their numbers in this assay, from the lowest: compound 2; then compounds 1 and 3 (each within the scatter of the next); then compound 4.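

Swapping methoxycarbonyl for trifluoromethyl in this assay gives a number 73 percentage points higher from compound 2 to compound 4 (beyond the scatter), so the choice of group at this position has a large effect on the read-out, even though both groups have 4 heavy atoms. Until now, this position had shown only a loss, a number 29 percentage points lower from compound 1 to compound 2 (beyond the scatter), but trifluoromethyl in place of hydrogen gives a number 44 percentage points higher from compound 1 to compound 4 (beyond the scatter), so a group here can raise the number as well as lower it. Nothing shown here explains the difference between these two groups.

As far as these compounds go, it remains open whether other groups at this position, such as a nitrile, a carboxylic acid or an amine, would behave more like trifluoromethyl or like methoxycarbonyl. These numbers also come from a single concentration, so they leave the potency of compound 4 open.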